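A few compounds are considered here, and "the series" means these few. Any claim that something is new, unique, unknown or untested is made for them only; others in the source may bear on it.

Measured compounds in a functional assay on OVCAR-8 cells (Homo sapiens) for inhibition, read by sulforhodamine B assay, with a stated time of 48 h; a lower number here means a stronger inhibitor of growth, a higher number a weaker inhibitor of growth:
compound 1 `N#Cc1c(-c2nnc(O)c3nn(-c4ccccc4)cc23)nn(-c2ccccc2)c1-c1ccccc1`: 61500 nM
compound 2 `N#Cc1c(-c2nnc(O)c3nn(-c4ccc(Cl)cc4)cc23)nn(-c2ccccc2)c1-c1ccccc1`: 3230 nM
compound 3 `N#Cc1c(-c2nnc(-c3nn(-c4ccccc4)c(-c4ccccc4)c3C#N)c3nn(-c4ccccc4)cc23)nn(-c2ccccc2)c1-c1ccccc1`: 9820 nM

Compound 1 and compound 2 share one core and differ in a single place: chloro in place of hydrogen on an aromatic carbon. In this assay that step was a 19-fold lower number from compound 1 to compound 2 (1.28 log units; beyond the scatter), the one large movement within the set so far.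

Compound 3 carries a second core. How that core differs from the core of compound 1 is not broken down here. In this assay compound 3 gives 9820 nM, a number that lies between those of compound 2 and compound 1, beyond the scatter of each.

Compound 4 `N#Cc1c(-c2nnc(-c3nn(-c4ccccc4)c(-c4ccccc4)c3C#N)c3nn(-c4ccc(Cl)cc4)cc23)nn(-c2ccccc2)c1-c1ccccc1` has not been measured. It differs from compound 3 in one place: chloro in place of hydrogen on an aromatic carbon. The place reads the same, word for word, as for the step from compound 1 to compound 2, so this is the same change, applied now to the core of compound 3. The change has been seen once in the series, so its size on this core is not secured.

Among the compounds with values here, for compound 4 in this assay a step of a 4.9-fold lower number from compound 3 to compound 4 (0.69 log units; beyond the scatter) is expected, smaller than the earlier one, because the single precedent is a 19-fold lower number from compound 1 to compound 2 (1.28 log units; beyond the scatter) and one example cannot fix the size on a different core. The estimate for compound 4 is 2000 nM, expected to fall between 600 nM and 7000 nM.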

Compound 4, concentration for 50% growth inhibition: 61800 nM
Beside the measured number, compound 4's estimate is 31-fold (1.49 log units) below it; measured number above the stated range.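

In this assay, the change from phenyl to 4-chlorophenyl does not carry over from one core to the other with a common size or direction: the same change on two cores in this assay, a 19-fold lower number (1.28 log units; beyond the scatter) from compound 1 to compound 2 and a 6.3-fold higher number (0.80 log units; beyond the scatter) from compound 3 to compound 4, 120-fold (2.08 log units) apart, beyond the scatter of two such steps. On the core of compound 3 the change gives a 6.3-fold higher number from compound 3 to compound 4 (0.80 log units; beyond the scatter), so the lower number seen on the core of compound 1 cannot be assumed for another core in this series. Within the data shown here, with only one matched pair per core, this shows that the effect of chloro depends on the core, but it does not show which feature of the core reverses the direction, nor how either core would respond to a different group at this place.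

Still open, from the compounds shown here alone, is whether a fluoro, a methoxy, an amine or a carboxylic acid on the same aromatic carbon, para to the same large group, would follow the step on the core of compound 1, the step on the core of compound 3, or neither. Also open, going by these compounds, is whether chloro on one of the other phenyl rings of these cores would give steps that agree across the two cores.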